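Para-substituent swap on the anilino ring: bromo to sulfamoyl

A few compounds are considered here, and "the series" means these few. Any claim that something is new, unique, unknown or untested is made for them only; others in the source may bear on it.

Compound 1 `Cc1nccn1-c1csc(Nc2ccccc2)n1` gives 32500 nM in a functional assay on RKO cells (Homo sapiens) for cytotoxicity, read by resazurin assay, with a stated time of 72 h; a higher number here means a weaker inhibitor, a lower number a stronger inhibitor. Within the data shown here, compound 2 `Cc1nccn1-c1csc(Nc2ccc(Br)cc2)n1` gives 30000 nM, the lower of the two numbers, with a 1.1-fold lower number from compound 1 to compound 2 (0.03 log units; within the scatter) as the only step so far. Compound 3 `Cc1nccn1-c1csc(Nc2ccc(S(N)(=O)=O)cc2)n1` differs from compound 2 by sulfamoyl in place of bromo on an aromatic carbon. Among the measured compounds shown here, no measured step exchanges bromo for sulfamoyl, and the one step, from hydrogen to bromo, stayed within the scatter, so nothing supports a shift beyond it. The step expected is no change at the digits printed from compound 2 to compound 3 (within the scatter). Compound 3 is estimated at 30000 nM, with a range of 10000 nM to 90000 nM.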

Compound 3, half-maximal inhibitory concentration: 49000 nM
Estimate against measurement, compound 3: 1.6-fold (0.21 log units) below, and the stated range covers the measured number.
By their numbers in this assay, from the lowest: compounds 2, 1 and 3 (each within the scatter of the next).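

Sulfamoyl in place of bromo gives a 1.6-fold higher number from compound 2 to compound 3 (0.21 log units; within the scatter) in this assay and, in place of hydrogen, a 1.5-fold higher number from compound 1 to compound 3 (0.18 log units; within the scatter) at the same position on the ring. Hydrogen, bromo and sulfamoyl, the last carrying a hydrogen-bond donor and hydrogen-bond acceptors, thus all give numbers within the scatter of each other at this position. Nothing measured here speaks to why the number stays in this range. From the compounds shown here alone, whether an amine, a carboxylic acid or a longer chain at this position would shift the number beyond the scatter stays open. So does the effect of changes elsewhere on the shared core.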